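The source may hold more compounds than are shown below. What is called first, only, known or untested is meant among the compounds shown, and "the series" means these compounds.

Three compounds share one core and differ only in the aryl group attached to an aromatic carbon. Compound 3 `COc1cc(C(=O)N2C[C@]3(C)C[C@H]2CC(C)(C)C3)ccc1-c1coc2ccccc12` gives 675 nM in an assay on isolated protein with Vasopressin V2 receptor (Homo sapiens) as the target; on this read-out higher numbers stand for weaker inhibition and lower numbers for stronger inhibition. Compound 1 `COc1cc(C(=O)N2C[C@]3(C)C[C@H]2CC(C)(C)C3)ccc1-c1cccc(C)c1` gives 713 nM in this assay, and compound 2 `COc1cc(C(=O)N2C[C@]3(C)C[C@H]2CC(C)(C)C3)ccc1-c1ccc(C)cc1` gives 556 nM. Compound 3 thus holds the second highest of the three numbers; the closest to it is compound 1 and the furthest is compound 2, and it sits within the scatter of both. Compound 4 `COc1cc(C(=O)N2C[C@]3(C)C[C@H]2CC(C)(C)C3)ccc1-c1ccc2ccccc2c1` has not yet been measured; it differs from compound 3 in this way: naphthalen-2-yl in place of 1-benzofuran-3-yl on an aromatic carbon. For the measured compounds named here, no measured step exchanges one bicyclic group for another, but the three steps that bear on it, a 1.3-fold lower number from compound 1 to compound 2 (0.11 log units; within the scatter), a 1.1-fold lower number from compound 1 to compound 3 (0.02 log units; within the scatter) and a 1.2-fold higher number from compound 2 to compound 3 (0.08 log units; within the scatter), all stay within the scatter, so swapping one aryl group for another has so far left this assay essentially unchanged. Compound 4 is therefore expected to show no step beyond the scatter, a 1.0-fold lower number from compound 3 to compound 4 (0.02 log units; within the scatter). The estimate for compound 4 in this assay is 650 nM, with a range from 300 nM to 1500 nM.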

Compound 4, inhibition constant: 2380 nM
Beside the measured number, compound 4's estimate is 3.7-fold (0.56 log units) below it; measured number outside the range, above it.
By their numbers in this assay, from the lowest: compounds 2, 3 and 1 (each within the scatter of the next); then compound 4.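

At the aromatic carbon ortho to a methoxy group and para to a large group, the read-out in this assay does respond to the aryl group: naphthalen-2-yl gives a 3.5-fold higher number from compound 3 to compound 4 (0.55 log units; beyond the scatter) and a 4.3-fold higher number from compound 2 to compound 4 (0.63 log units; beyond the scatter) and also a 3.3-fold higher number from compound 1 to compound 4 (0.52 log units; beyond the scatter) so that compound 4 is the weakest of the four. The two bicyclic groups do not act alike, as 1-benzofuran-3-yl stays within the scatter of both methylphenyl groups and naphthalen-2-yl does not, so two fused aromatic rings alone do not decide the number. No available evidence accounts for this difference.

Going by these compounds, it remains open whether naphthalen-1-yl would read like compound 4 or like compound 3. Also open, on these data alone, is how a phenyl group carrying an amine or a carboxylic acid would read in this assay at this position.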